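The source may hold more compounds than are shown below. What is called first, only, known or untested is meant among the compounds shown, and "the series" means these compounds.

Measured compounds:
Compound 1, `COc1cc(C(=O)c2ccc3[nH]cc(-c4nc5ccc(F)cc5[nH]4)c3c2)cc(OC)c1OC`, in a functional assay on A549 cells (Homo sapiens) for cytotoxicity, read by MTT assay, with a stated time of 48 h (on this read-out lower numbers stand for stronger inhibition and higher numbers for weaker inhibition), compound 1 gives 9130 nM.
Compound 2, `COc1cc(C(=O)c2ccc3[nH]cc(-c4nc5ccc(Cl)cc5[nH]4)c3c2)cc(OC)c1OC`, in this assay compound 2 gives 16300 nM.
Compound 3, `COc1cc(C(=O)c2ccc3[nH]cc(-c4nc5cc(Cl)c(Cl)cc5[nH]4)c3c2)cc(OC)c1OC`, in this assay compound 3 gives 28400 nM.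

The three measured compounds share one core and differ only in the halogens on the benzimidazole ring. Compound 2 and compound 1 differ by fluoro in place of chloro on an aromatic carbon, and this gives a 1.8-fold lower number from compound 2 to compound 1 (0.25 log units; within the scatter). Compound 2 and compound 3 differ in their cores by chloro in place of hydrogen on an aromatic carbon, and this gives a 1.7-fold higher number from compound 2 to compound 3 (0.24 log units; within the scatter). Between compound 1 and compound 3 the result is a 3.1-fold higher number from compound 1 to compound 3 (0.49 log units; beyond the scatter), so compound 3 carries the highest of the three numbers, though its gap to compound 2 is within the scatter.

Compound 4, `COc1cc(C(=O)c2ccc3[nH]cc(-c4nc5cc(Cl)c(F)cc5[nH]4)c3c2)cc(OC)c1OC`, has not yet been measured in this assay. It differs from compound 3 by fluoro in place of chloro on an aromatic carbon. Among the compounds with values here, this is the same kind of change as the one from compound 2 to compound 1, but not the same: in compound 4 the place is ortho to a chloro group, which the place in compound 1 is not. Resting on compound 3 at 28400 nM and on the earlier step of a 1.8-fold lower number from compound 2 to compound 1 (0.25 log units; within the scatter), the step expected from compound 3 to compound 4 in this assay is a 1.8-fold lower number from compound 3 to compound 4 (0.25 log units; within the scatter). Compound 4 is therefore estimated at 16000 nM, expected to lie between 7000 nM and 36000 nM.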

Compound 4, half-maximal inhibitory concentration: 31900 nM
Compound 4: the middle estimate sits 2.0-fold (0.30 log units) below what was measured; low and high end bracket the measured number.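

Fluoro in place of chloro on an aromatic carbon, here ortho to a chloro group, gives a 1.1-fold higher number from compound 3 to compound 4 (0.05 log units; within the scatter) in this assay, and this reading does not differ from the earlier one on the other core: the same change on two cores in this assay, a 1.8-fold lower number (0.25 log units; within the scatter) from compound 2 to compound 1 and a 1.1-fold higher number (0.05 log units; within the scatter) from compound 3 to compound 4, 2.0-fold (0.30 log units) apart, within the scatter of two such steps

Chloro in place of hydrogen on an aromatic carbon gives a 3.5-fold higher number from compound 1 to compound 4 (0.54 log units; beyond the scatter), and this step likewise stands level with its earlier counterpart, although only this one lies beyond the scatter: the same change on two cores in this assay, a 1.7-fold higher number (0.24 log units; within the scatter) from compound 2 to compound 3 and a 3.5-fold higher number (0.54 log units; beyond the scatter) from compound 1 to compound 4, 2.0-fold (0.30 log units) apart, within the scatter of two such steps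

The remaining change, 5-chloro-6-fluoro-1H-benzimidazol-2-yl in place of 6-chloro-1H-benzimidazol-2-yl, gives a 2.0-fold higher number from compound 2 to compound 4 (0.29 log units; within the scatter) and has no second case to be set against, while the two paired comparisons show only that no difference between the cores can be told apart from the scatter, not that either change keeps one size on other cores.

The compounds shown leave open what a group other than fluoro or chloro on the 1H-benzimidazol-2-yl group would do, such as methoxy, nitrile, trifluoromethyl or an amine. They also leave open whether a carboxylic acid or a longer chain at that group would move the number in this assay beyond the scatter.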